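The source may report more compounds than this note shows. Statements on the series, on what has been measured and on what is new or still open speak of the compounds shown alone.

Measured so far:

Compound 1, `C=CCc1cc(O)c(O)c(CN2CCC(CO)CC2)c1`, gives 34.1% in a functional assay on MIA PaCa-2 cells (Homo sapiens) for inhibition, read by MTT assay, with a stated time of 72 h, tested at 30 uM; on this read-out lower numbers stand for less inhibition of growth and higher numbers for more inhibition of growth at the one concentration tested.
Compound 2, `C=CCc1ccc(OCc2cn(-c3ccccc3Cl)nn2)c(O)c1`, gives 46.6% in this assay.
Compound 3, `C#CCOc1ccc(CC=C)cc1O`, gives 27.4% in this assay.

Among these three, compound 2 stands highest, and both gaps below it go beyond the usual scatter: compound 1 lies closest, and compound 3 lies furthest away. So compound 2 is the strongest grower-inhibitor of the three on this read-out.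

The unmeasured compound 4, `C=CCc1ccc(OCc2cn(-c3ccc(Br)cc3)nn2)c(O)c1`, keeps the shared core of compound 2 and differs from it in one place:

4-bromophenyl in place of 2-chlorophenyl on an aromatic nitrogen

Within the data shown here, no step between two measured compounds traces a change of this kind, so nothing measured here tells how swapping one halogen-bearing phenyl for another on the aromatic nitrogen moves the number. The two groups are counted alike in size, in donors and acceptors and in charge. The expectation is therefore a step from compound 2 to compound 4 of a number 2.6 percentage points lower from compound 2 to compound 4 (within the scatter), that is, a change that stays within the scatter rather than a clear move in either direction. Compound 4 is expected to give about 44% in this assay, with a likely range from 26% to 62%.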

Compound 4, percent growth inhibition at one concentration: 43.3%
The estimate for compound 4 lay 0.7 percentage points above the measured number, within the range that was stated.
By their numbers in this assay, from the lowest: compounds 3, 1, 4 and 2 (each within the scatter of the next, the first and the last beyond it).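

Among these compounds, replacing 2-chlorophenyl with 4-bromophenyl on the aromatic nitrogen gives a number 3.3 percentage points lower from compound 2 to compound 4 (within the scatter) in this assay, the first step that can be read at this place. This position therefore accepts one halogen-bearing phenyl in place of another with no difference that stands clear of the scatter, at least for this pair of groups. The kind of halogen and its place on the phenyl both differ in this single step, so their separate contributions cannot be told apart, and no measurement shown offers an explanation for the close agreement between the two compounds.

As far as these compounds go, a 4-chlorophenyl or a 2-bromophenyl group on the same nitrogen would change only one of those two features, so the separate roles of the halogen and its place remain open. Also open, from the compounds shown here alone, is how far this position depends on a halogen-bearing phenyl at all, a question that an unsubstituted phenyl, a 4-aminophenyl, a 4-carboxyphenyl or a longer alkyl chain in the same place would address.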